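From Ethoxycarbonyl to Phenyl on a Saturated Ring Carbon

The source may report more compounds than this note shows. Statements on the series, on what has been measured and on what is new or still open speak of the compounds shown alone.

Measured so far in a functional assay on DU-145 cells (Homo sapiens) for antiproliferative activity, read by MTT assay, with a stated time of 72 h; on this read-out lower numbers stand for stronger inhibition and higher numbers for weaker inhibition:
compound 1 `COc1cc2c(Nc3ccc(C#N)cc3)ncnc2cc1OCCCN1CCC(O)CC1` gives 74900 nM;
compound 2 `COc1cc2c(Nc3ccc(C#N)cc3)ncnc2cc1OCCCN1CCC(CO)CC1` gives 53200 nM;
compound 3 `CCOC(=O)C1CCN(CCCOc2cc3ncnc(Nc4ccc(C#N)cc4)c3cc2OC)CC1` gives 52300 nM.

Compound 3 carries the lowest of the three numbers, but its steps to both neighbours lie within the scatter: a 1.4-fold lower number from compound 1 to compound 3 (0.16 log units; within the scatter) and a 1.0-fold lower number from compound 2 to compound 3 (0.01 log units; within the scatter). Compound 4 `COc1cc2c(Nc3ccc(C#N)cc3)ncnc2cc1OCCCN1CCC(c2ccccc2)CC1` differs from compound 3 by phenyl in place of ethoxycarbonyl on a saturated ring carbon. Going by the values given here, no measured step covers this exact change; the closest comparisons are the three swaps at the same ring carbon, including a 1.4-fold lower number from compound 1 to compound 2 (0.15 log units; within the scatter), and all of them stay within the scatter. Since every group tried there left the read-out in this assay essentially unchanged, compound 4 is expected to show no step beyond the scatter, a 1.2-fold lower number from compound 3 to compound 4 (0.07 log units; within the scatter). Compound 4 is therefore estimated at 45000 nM, with a range from 15000 nM to 120000 nM.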

Compound 4, half-maximal inhibitory concentration: 6790 nM
For compound 4 the middle estimate is 6.6-fold (0.82 log units) above the measured one, outside the stated range (below it).
By their numbers in this assay, from the lowest: compound 4; then compounds 3, 2 and 1 (each within the scatter of the next).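

At the saturated ring carbon three ring bonds from the ring nitrogen, the read-out in this assay proves sensitive to the group after all: phenyl gives a 7.7-fold lower number from compound 3 to compound 4 (0.89 log units; beyond the scatter), a 7.8-fold lower number from compound 2 to compound 4 (0.89 log units; beyond the scatter) and an 11-fold lower number from compound 1 to compound 4 (1.04 log units; beyond the scatter), while hydroxy, hydroxymethyl and ethoxycarbonyl stay within the scatter of one another. Of these four groups, only phenyl carries an aromatic ring. Nothing available here bears on why this step occurs.

The compounds shown leave open whether a cyclohexyl group, a benzyl group or a pyridyl ring at this carbon would give a similar step.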